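The compounds below may be only part of what the source reports. "The series", "measured", "known", "first", "only" and "open" are said of these compounds alone.

In a functional assay on HT-29 cells (Homo sapiens) for inhibition, read by MTT assay, with a stated time of 48 h (on this read-out lower numbers stand for stronger inhibition and higher numbers for weaker inhibition), compound 1 `COc1cc(-c2nnc(SCc3ccccc3)n2-c2ccc(N(C)C)cc2)cc(OC)c1OC` gives > 60000 nM, which is a limit of the assay and not a number. Among the measured compounds shown here, compound 2 `COc1cc(-c2nnc(SCc3ccc(C)cc3)n2-c2ccc(N(C)C)cc2)cc(OC)c1OC` gives 27500 nM, the only true number so far. For the measured compounds named here, the single measured step is an at least 2.1-fold lower number from compound 1 to compound 2 (0.33 log units; beyond the scatter), for methyl in place of hydrogen on an aromatic carbon. Its size is open-ended, since it rests on (the limit of > 60000 nM in this assay, at which 1 of the 2 values shown sits).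

Compound 3 `COc1cc(-c2nnc(SCc3ccc(F)cc3)n2-c2ccc(N(C)C)cc2)cc(OC)c1OC` changes the same place: fluoro in place of methyl on an aromatic carbon, para to a large group. Going by the values given here, no measured step covers fluoro, so the methyl step is the only guide. Losing that methyl suggests a modest move back toward weaker inhibition in this assay. The expected change is a 1.5-fold higher number from compound 2 to compound 3 (0.16 log units; within the scatter), possibly little beyond the scatter. For compound 3 the estimated value is 40000 nM, with an expected range of 18000 nM to 80000 nM.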

Compound 3, half-maximal inhibitory concentration: 44300 nM
Beside the measured number, compound 3's estimate is 1.1-fold (0.04 log units) below it; the measured number falls inside the stated range.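

At the position para to a large group in this assay, the second substituent gives a 1.6-fold higher number from compound 2 to compound 3 (0.21 log units; within the scatter), so fluoro in place of methyl separates 4-fluorobenzyl from 4-methylbenzyl by no more than the scatter. Against the unsubstituted benzyl compound, the reading is an at least 1.3-fold lower number from compound 1 to compound 3 (0.13 log units; that floor lies within the scatter), so fluoro in place of hydrogen cannot yet be shown to have any effect. The true size of that step stays unknown because one end of it is an assay limit: the limit of > 60000 nM in this assay, at which 1 of the 3 values shown sits.

Still open, as far as these compounds go, is the true number behind the limit for compound 1, on which any reading of the two substituents against hydrogen depends. The compounds shown also give no guide to how an amine, a carboxylic acid or a longer chain would read at this same place.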